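Hydroxy in place of fluoro: working notes on the series

A few compounds are considered here, and "the series" means these few. Any claim that something is new, unique, unknown or untested is made for them only; others in the source may bear on it.

In a functional assay on DWD cells (Homo sapiens) for inhibition, read by sulforhodamine B assay (on this read-out lower numbers stand for stronger inhibition of growth and higher numbers for weaker inhibition of growth), compound 1 `Fc1ccc(-c2ccc(-c3ccc(-c4nc5ccccc5[nH]4)cc3)cc2)cc1` gives 35600 nM, compound 2 `Cc1ccc2[nH]c(-c3ccc(-c4ccc(-c5ccccc5)cc4)cc3)nc2c1` gives 28300 nM and compound 3 `Cc1ccc2[nH]c(-c3ccc(-c4ccc(-c5ccc(F)cc5)cc4)cc3)nc2c1` gives 33100 nM. Compound 3 therefore stands among two close neighbours, and all three numbers lie within the scatter of one another.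

The next compound is compound 4 `Cc1ccc2[nH]c(-c3ccc(-c4ccc(-c5ccc(O)cc5)cc4)cc3)nc2c1`, which differs from compound 3 at one place: hydroxy in place of fluoro on an aromatic carbon. This is hydroxy in place of fluoro on an aromatic carbon, para to a large group, or 4-fluorophenyl to 4-hydroxyphenyl.

Within the data shown here, two measured steps bear on it. The closer one is fluoro in place of hydrogen, which gave a 1.2-fold higher number from compound 2 to compound 3 (0.07 log units; within the scatter). It concerns the same place as the new change. The other is methyl in place of hydrogen, which gave a 1.1-fold lower number from compound 1 to compound 3 (0.03 log units; within the scatter). Among the measured compounds shown here, it shows only that the methyl group made no difference beyond the scatter. For the measured compounds named here, no measured compound carries a hydroxy group, so the size of this change remains untested and the range must stay wide.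

No clear direction can be drawn from these data, and no change beyond the scatter is the working expectation. The expected step is a 1.2-fold lower number from compound 3 to compound 4 (0.09 log units; within the scatter). For compound 4 the estimated value is 27000 nM, with an expected range of 10000 nM to 65000 nM.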

Compound 4, concentration for 50% growth inhibition: 21200 nM
Beside the measured number, compound 4's estimate is 1.3-fold (0.11 log units) above it; the range from low to high includes it.
By their numbers in this assay, from the lowest: compounds 4, 2, 3 and 1 (each within the scatter of the next).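

Hydroxy in place of fluoro gives a 1.6-fold lower number from compound 3 to compound 4 (0.19 log units; within the scatter) in this assay and hydroxy in place of hydrogen gives a 1.3-fold lower number from compound 2 to compound 4 (0.13 log units; within the scatter) on the same core, so the earlier reading of a single substitution at this place now extends to a second group. Hydrogen, fluoro and hydroxy on the terminal phenyl ring of the methyl-bearing core thus form a set of three compounds, 2, 3 and 4, with no step among those shown beyond the scatter, even though hydroxy brings one hydrogen-bond donor and one hydrogen-bond acceptor where fluoro brings neither. No measured evidence available here bears on why these compounds read alike.

On these data alone, whether any group at this place can move the number beyond the scatter remains open, for instance an amine, a carboxylic acid or a methoxy group in the same position on the aromatic ring. Also open, as far as these compounds go, is whether 4-hydroxyphenyl would read the same way on the core of compound 1, which lacks the methyl group.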